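This account rests on a few compounds, and the source may have more. Where it says the series, first, only, none or still open, it means among the compounds named here.

Measured compounds:
compound 1 `Cc1cc(C)cc(Cc2ccc3c(NCCCNCc4ccco4)ccnc3c2)c1` — 9.47
compound 2 `CC(C)(C)c1ccc(-c2ccc3c(NCCCNCc4ccco4)ccnc3c2)cc1` — 9.47

In a physicochemical assay for acid dissociation, compound 2 gives 9.47, level with compound 1 at the digits shown; the single measured step, no change at the digits printed from compound 1 to compound 2 (within the scatter), is a swap of the group on the same aromatic carbon and leaves the read-out unchanged within the scatter.

Compound 3 `COc1ccccc1Oc1ccc2c(NCCCNCc3ccco3)ccnc2c1` is the next case at that position. The change is 2-methoxyphenoxy in place of 4-(tert-butyl)phenyl on an aromatic carbon. Among the measured compounds shown here, the only step that bears on it is the one from compound 1 to compound 2, where a different replacement at the same site gave no change. On that basis no movement in this assay beyond the scatter is expected for compound 3, in either direction; the expected step is a number 0.02 log units lower from compound 2 to compound 3 (within the scatter). The estimate for compound 3 in this assay is 9.45, expected to lie between 9.15 and 9.75.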

Compound 3, acid dissociation constant: 9.28
The estimate for compound 3 lay 0.17 log units above the measured number; the measured number falls inside the stated range.
By their numbers in this assay, from the lowest: compounds 3, 1 and 2 (each within the scatter of the next).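

In this assay the swap to 2-methoxyphenoxy on this aromatic carbon gives a number 0.19 log units lower from compound 2 to compound 3 (within the scatter) and the same group gives a number 0.19 log units lower from compound 1 to compound 3 (within the scatter) when set against 3,5-dimethylbenzyl. Among the compounds shown here, three different groups at this position now sit within the scatter of one another, and this holds for the first group that carries oxygen and hydrogen-bond acceptors, where 4-(tert-butyl)phenyl has neither. No supporting measurement is available to explain these numbers.

Still open, going by these compounds, is whether a group of another kind on this carbon, such as an amine or a carboxylic acid, would move the read-out beyond the scatter. Also open, on these data alone, is how the read-out responds to a change elsewhere on the molecule, as all three compounds share the same core and the same side chain.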